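Swapping the ether group on compound 2

A few compounds are considered here, and "the series" means these few. Any claim that something is new, unique, unknown or untested is made for them only; others in the source may bear on it.

Measured so far in an ADME assay on microsomes from liver (Homo sapiens) for metabolic stability (a higher number here means faster removal of the compound, a lower number slower removal), are two compounds:
Compound 1 `CCn1cnc2c(-c3ccc(F)c(OCc4ccccn4)c3)cnnc21` gives 41 mL.min-1.g-1 as a number
Compound 2 `CC(=O)N1CC(Oc2cc(-c3cnnc4c3ncn4C(C)C)ccc2F)C1` gives < 8 mL.min-1.g-1 as a limit

Compound 2 carries no number in this assay and stands only at a limit (the limit of < 8 mL.min-1.g-1 in this assay, at which 1 of the 2 values shown sits). Compound 3 `CC(C)n1cnc2c(-c3ccc(F)c(Oc4ccc(C#N)cn4)c3)cnnc21` has yet to be measured. It departs from compound 2 in one place, where 5-cyanopyridin-2-yl stands in place of 1-acetylazetidin-3-yl on an oxygen on an aromatic ring (5-cyanopyridin-2-yl in place of 1-acetylazetidin-3-yl on an oxygen on an aromatic ring). Among the compounds with values here, no pair of measured compounds differs in a single place, so no measured step sets the size of this change. The expectation therefore leans on compound 1 at 41 mL.min-1.g-1 whose ether group also ends in an aromatic ring. A move toward faster removal, beyond the usual scatter, is expected, and the estimated step is an at least 3.1-fold higher number from compound 2 to compound 3 (0.49 log units; beyond the scatter) in this assay on this reasoning. For compound 3 the expected value is 25 mL.min-1.g-1 with an estimated range from 10 mL.min-1.g-1 to 60 mL.min-1.g-1 at the two ends.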

Compound 3, intrinsic clearance in microsomes in the Homo sapiens assay: 38 mL.min-1.g-1
The estimate for compound 3 lay 1.5-fold (0.18 log units) below the measured number; the range from low to high includes it.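

Within the data shown here, in the Homo sapiens assay, putting 5-cyanopyridin-2-yl in place of 1-acetylazetidin-3-yl on an oxygen on an aromatic ring gives an at least 4.7-fold higher number from compound 2 to compound 3 (0.67 log units; beyond the scatter), the first measured step at this position, and it is beyond the scatter. The size of this step is open at its upper end, as compound 2 carries only a limit and no number: the limit of < 8 mL.min-1.g-1 in the Homo sapiens assay, at which 1 of the 3 values shown sits. In a physicochemical assay for lipophilicity (on this read-out higher numbers stand for higher lipophilicity and lower numbers for lower lipophilicity), compound 2 gives 1.6 and compound 3 gives 2.7 as measured numbers. In the physicochemical assay, faster removal comes together with higher lipophilicity in this same pair: the measured distribution coefficient of compound 2, 1.6, and of compound 3, 2.7, a number 1.10 log units higher (beyond the scatter)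

From the compounds shown here alone, a single pair cannot separate these readings, so it remains open whether the step in the Homo sapiens assay follows the aromatic ring, the nitrile or the rise in lipophilicity. Also open, going by these compounds, is how removal would respond to a plain pyridin-2-yl without the nitrile, or to an azetidine that carries a free amine instead of the acetyl group.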